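A Methoxy Group Added to a Weakly Active Sulfone

The source may hold more compounds than are shown below. What is called first, only, known or untested is meant among the compounds shown, and "the series" means these compounds.

Compound 1 `CSc1ccc(-c2nc3ccc[nH]c-3n2)cc1` and compound 2 `CS(=O)(=O)c1ccc(-c2nc3ccc[nH]c-3n2)cc1` share one core and differ in a single group. Among the measured compounds shown here, in a functional assay on the whole organism with Canis familiaris (Canis lupus familiaris) as the target (on this read-out lower numbers stand for an effect already at smaller amounts and higher numbers for an effect only at larger amounts of compound), compound 1 gives 1.9 mg/kg, while compound 2 gives 18 mg/kg, the highest of the two numbers measured so far: a 9.5-fold higher number from compound 1 to compound 2 (0.98 log units; beyond the scatter). Compound 3 `COc1cc(S(C)(=O)=O)ccc1-c1nc2ccc[nH]c-2n1` keeps the methylsulfonyl group of compound 2 and carries one further change: methoxy in place of hydrogen on an aromatic carbon. For the measured compounds named here, no measured step covers a methoxy in place of hydrogen at this place; the one step measured, methylsulfonyl in place of methylsulfanyl, concerns a different group and offers no direct guide. Any step a 1.2-fold lower number from compound 2 to compound 3 (0.08 log units; within the scatter) is therefore expected to remain within the usual scatter. Compound 3 is estimated at 15 mg/kg, with a likely range from 5 mg/kg to 45 mg/kg.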

Compound 3, dose for half-maximal effect: 0.4 mg/kg
For compound 3 the middle estimate is 38-fold (1.57 log units) above the measured one; the whole stated range lies above it.
By their numbers in this assay, from the lowest: compound 3; then compound 1; then compound 2.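

In this assay methoxy in place of hydrogen brings a 45-fold lower number from compound 2 to compound 3 (1.65 log units; beyond the scatter) and so this place on the ring, ortho to a group of 9 heavy atoms and meta to a methylsulfonyl group, matters strongly for the dose needed. A group of only 2 heavy atoms here gives a large step, beyond the scatter, whereas the earlier change from methylsulfanyl to methylsulfonyl (a 9.5-fold higher number from compound 1 to compound 2 (0.98 log units; beyond the scatter)) was modest and ran in the opposite direction. Compound 3 also shows that keeping methylsulfonyl does not by itself tie a compound to the high number of compound 2.

Nothing available explains why methoxy has this effect. The compounds shown leave open whether a hydroxyl, an ethoxy chain or an amine at this place would act alike, and whether methoxy would give a similar step on compound 1.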